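Bromo for Methoxy on a Weakly Cytotoxic Amide Series

The source may report more compounds than this note shows. Statements on the series, on what has been measured and on what is new or still open speak of the compounds shown alone.

Compound 1 `O=C(Nc1ccc(Oc2ccnc3[nH]ccc23)cc1)c1nn(-c2ccc(Br)cc2)ccc1=O` gives in a functional assay on A549 cells (Homo sapiens) for cytotoxicity, read by MTT assay, with a stated time of 72 h (on this read-out higher numbers stand for weaker inhibition and lower numbers for stronger inhibition), 6240 nM.
Compound 2 `Cn1ccc2c(Oc3ccc(NC(=O)c4nn(-c5ccc(Cl)cc5)ccc4=O)cc3)ccnc21` reaches only a limit of the assay, > 60000 nM.
Compound 3 `COc1ccc(-n2ccc(=O)c(C(=O)Nc3ccc(Oc4ccnc5c4ccn5C)cc3)n2)cc1` likewise reaches only a limit of the assay, > 60000 nM.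

Compound 3 thus stands at the limit noted here: the limit of > 60000 nM in this assay, at which 2 of the 3 values shown sit. The step from compound 2 to compound 3 cannot be read, a step that the two limits leave unreadable from compound 2 to compound 3. Compound 4 `Cn1ccc2c(Oc3ccc(NC(=O)c4nn(-c5ccc(Br)cc5)ccc4=O)cc3)ccnc21` differs from compound 3 by bromo in place of methoxy on an aromatic carbon. Going by the values given here, no measured step from compound 3 bears on this change; among the measured compounds only compound 1, which also carries bromo, has a readable value, while compound 2 and compound 3 do not. The step of an at least 1.2-fold lower number from compound 3 to compound 4 (0.07 log units; that floor lies within the scatter) is therefore an estimate resting on little. Compound 4 is expected at 50000 nM, between 15000 nM and 150000 nM, and most likely again only a limit.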

Compound 4, half-maximal inhibitory concentration: 59400 nM
Compound 4: the middle estimate sits 1.2-fold (0.07 log units) below what was measured; the measured number falls inside the stated range.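

With bromo held fixed, methyl in place of hydrogen on an aromatic nitrogen gives a 9.5-fold higher number from compound 1 to compound 4 (0.98 log units; beyond the scatter) and so a modest step toward weaker inhibition. Going by these compounds alone, this is the first change with a readable size, and it shows that in this assay the hydrogen on this nitrogen matters. Neither a number no higher from compound 2 to compound 4 (the limit leaves the size open) nor a number no higher from compound 3 to compound 4 (the limit leaves the size open) has a size that can be read, so the change from 4-methoxyphenyl to 4-bromophenyl still has no size: the limit of > 60000 nM in this assay, at which 2 of the 4 values shown sit.

As far as these compounds go, it remains open what an ethyl group or a longer chain on that nitrogen would give. From the compounds shown here alone, it also remains open what an amine or a nitrile would give in place of bromo.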